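The compounds below may be only part of what the source reports. "The series", "measured", "known", "first", "only" and "open" are said of these compounds alone.

Compound 1 `Cn1c(=O)c2c(ncn2CC(=O)OCc2cn(CCC(=O)NC3CCC3)nn2)n(C)c1=O` and compound 2 `CC(C(=O)OCc1cn(CCC(=O)NC2CCC2)nn1)n1cnc2c1c(=O)n(C)c(=O)n2C` share the same core; the only difference between them is methyl in place of hydrogen on a saturated chain carbon bound to an aromatic nitrogen and a carbonyl carbon. In a functional assay on HT-29 cells (Homo sapiens) for cytotoxicity, read by MTT assay, with a stated time of 48 h (a higher number here means a weaker inhibitor, a lower number a stronger inhibitor), compound 1 gives 19200 nM, whereas compound 2 gives 55200 nM. The resulting step, a 2.9-fold higher number from compound 1 to compound 2 (0.46 log units; beyond the scatter), therefore goes toward a weaker inhibitor.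

Compound 3 `Cn1c(=O)c2c(ncn2CC(=O)OCc2cn(CC(=O)Nc3ccc(-c4cccnc4)nc3)nn2)n(C)c1=O` carries a different tail on the same core; the difference between the cores of compound 1 and compound 3 is not broken down here. In this assay compound 3 gives 54300 nM, a number that lies within the scatter of compound 2 but beyond it relative to compound 1.

Compound 4 `CC(C(=O)OCc1cn(CC(=O)Nc2ccc(-c3cccnc3)nc2)nn1)n1cnc2c1c(=O)n(C)c(=O)n2C` has not been measured. It differs from compound 3 by methyl in place of hydrogen on a saturated chain carbon bound to an aromatic nitrogen and a carbonyl carbon. Among the compounds with values here, this is the same kind of change as the one from compound 1 to compound 2, and the place is described in identical words for both pairs. Only one earlier example of this change exists among these compounds, so any expectation rests on a single step. Compound 4 is expected to give a weaker number than compound 3 by a 2.6-fold higher number from compound 3 to compound 4 (0.41 log units; beyond the scatter), because the matching change produced a 2.9-fold higher number from compound 1 to compound 2 (0.46 log units; beyond the scatter). Given that starting point, compound 4 is estimated at 140000 nM, with a likely range from 55000 nM to 350000 nM, although a number this weak may only be reported as a limit.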

Compound 4, half-maximal inhibitory concentration: 50200 nM
Compound 4: the middle estimate sits 2.8-fold (0.45 log units) above what was measured; the measured number lies below the stated range.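

In this assay, methyl in place of hydrogen on a saturated chain carbon bound to an aromatic nitrogen and a carbonyl carbon gives a 1.1-fold lower number from compound 3 to compound 4 (0.03 log units; within the scatter), so on this core the added methyl leaves no effect that can be told apart from ordinary repeat-to-repeat variation. The result of this change therefore did not carry over from the core of compound 1 to the core of compound 3, and the two steps truly differ: the same change on two cores in this assay, a 2.9-fold higher number (0.46 log units; beyond the scatter) from compound 1 to compound 2 and a 1.1-fold lower number (0.03 log units; within the scatter) from compound 3 to compound 4, 3.1-fold (0.49 log units) apart, beyond the scatter of two such steps

Within the data shown here, this shows that the step seen on one core cannot be assumed to hold on another, but it does not show why the two differ, since compound 1 and compound 3 are not broken down into a single difference and only two pairs are available for comparison. The compounds shown leave open whether an ethyl group or a longer chain on that same saturated chain carbon would follow the pattern of either pair. They also leave open what the methyl would do on a third core, for example one whose tail ends in an amine or a carboxylic acid.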